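Chain extension from compound 2 to compound 4

The source may report more compounds than this note shows. Statements on the series, on what has been measured and on what is new or still open speak of the compounds shown alone.

In a functional assay on A549 cells (Homo sapiens) for antiproliferative activity, read by MTT assay, with a stated time of 48 h (on this read-out lower numbers stand for stronger inhibition and higher numbers for weaker inhibition), compound 2 (`C#Cc1cccc(NC(=O)c2cc(NC(=O)CCCCCC(=O)NO)ccc2O)c1`) gives 76200 nM, the highest number in the series. Compound 1 (`O=C(CCCCCC(=O)Nc1ccc(O)c(C(=O)Nc2ccccc2)c1)NO`) gives 14600 nM and compound 3 (`O=C(CCCCCC(=O)Nc1ccc(O)c(C(=O)Nc2ccc(Cl)c(Cl)c2)c1)NO`) gives 17800 nM, two values within the scatter of each other.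

Compound 4 (`C#Cc1cccc(NC(=O)c2cc(NC(=O)CCCCCCC(=O)NO)ccc2O)c1`) keeps the aromatic end of compound 2 and changes the chain: (hydroxycarbamoyl)methyl in place of hydroxycarbamoyl on a saturated chain carbon, five bonds along the chain from a carbonyl carbon. In words, (hydroxycarbamoyl)methyl stands in place of hydroxycarbamoyl on a saturated chain carbon.

The measured steps all change the aromatic end: a 5.2-fold higher number from compound 1 to compound 2 (0.72 log units; beyond the scatter) and a 4.3-fold lower number from compound 2 to compound 3 (0.63 log units; beyond the scatter) are modest, while a 1.2-fold higher number from compound 1 to compound 3 (0.09 log units; within the scatter) stays within the scatter. None of them tests chain length, so they offer only a rough scale for the size of a step and no direct evidence of its direction. A lean towards a lower number rests only on the high position of compound 2, shown by a 4.3-fold lower number from compound 2 to compound 3 (0.63 log units; beyond the scatter).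

The expected step is a 2.2-fold lower number from compound 2 to compound 4 (0.34 log units; beyond the scatter), of modest size at most. For compound 4 the estimated value is 35000 nM, with an expected range from 12000 nM to 100000 nM.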

Compound 4, half-maximal inhibitory concentration: 43600 nM
Compound 4: middle estimate off by 1.2-fold (0.10 log units), on the low side; the measured number falls inside the stated range.
By their numbers in this assay, from the lowest: compounds 1 and 3 (each within the scatter of the next); then compounds 4 and 2 (each within the scatter of the next).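

Chain length now has a direct test at this position: in this assay there is a 1.7-fold lower number from compound 2 to compound 4 (0.24 log units; within the scatter) for (hydroxycarbamoyl)methyl in place of hydroxycarbamoyl. With the 3-ethynylphenyl end held fixed, this chain extension therefore gives no change beyond the scatter, so the high number of compound 2 is not shown to depend on chain length. No measurement on hand offers an explanation for this result.

On these data alone, whether the same extension behaves alike with the phenyl end of compound 1 or the 3,4-dichlorophenyl end of compound 3 remains open. Also open, as far as these compounds go, are a longer chain, such as 4-(hydroxycarbamoyl)butyl, and a carboxylic acid in place of the hydroxycarbamoyl end, which would show whether the chain and its end group can move the number beyond the scatter.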